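Aryl swap on the shared core: compound 3 to compound 4

The source may hold more compounds than are shown below. What is called first, only, known or untested is meant among the compounds shown, and "the series" means these compounds.

Measured so far:
compound 1 `COc1cc(-n2ncnc2-c2ccc(OC(C)C)cc2)cc(OC)c1OC` — 650 nM
compound 2 `COc1cc(-n2ncnc2-c2cccc(Cl)c2)cc(OC)c1OC` — a limit only, > 10000 nM
compound 3 `COc1cc(-n2ncnc2-c2ccc(Cl)c(Cl)c2)cc(OC)c1OC` — a limit only, > 10000 nM

In a functional assay on Jurkat cells (Homo sapiens) for antiproliferative activity, read by MTT assay, with a stated time of 72 h (on this read-out lower numbers stand for stronger inhibition and higher numbers for weaker inhibition), compound 3 stands at the limit; compound 2 stands there too, and (the limit of > 10000 nM in this assay, at which 2 of the 3 values shown sit). Going by the values given here, the single measured step, a step that the two limits leave unreadable from compound 2 to compound 3, is therefore unreadable. Compound 4 `COc1cc(-n2ncnc2-c2ccc(SC)cc2)cc(OC)c1OC` differs from compound 3 by 4-(methylsulfanyl)phenyl in place of 3,4-dichlorophenyl on an aromatic carbon. Among the compounds with values here, no measured step bears directly on this change; the only compound with a number is compound 1, which gives 650 nM in this assay. Compound 4 is expected to land between that value and the limit, an estimated 2000 nM (500 nM to 10000 nM), meaning an estimated step of an at least 5.0-fold lower number from compound 3 to compound 4 (0.69 log units; beyond the scatter).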

Compound 4, half-maximal inhibitory concentration: 50 nM
Compound 4: middle estimate off by 40-fold (1.60 log units), on the high side; the whole stated range lies above it.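

In this assay, changing only the aryl group on this carbon gives an at least 200-fold lower number from compound 3 to compound 4 (2.30 log units; beyond the scatter) and an at least 200-fold lower number from compound 2 to compound 4 (2.30 log units; beyond the scatter). Methylsulfanyl in place of isopropoxy also counts, with a 13-fold lower number from compound 1 to compound 4 (1.11 log units; beyond the scatter), the only new step readable at both ends. The other two steps start from a limit, so their full size stays unread: the limit of > 10000 nM in this assay, at which 2 of the 4 values shown sit.

Still open, going by these compounds, is whether the gain depends on the sulfur atom or on the small chain it carries. An ethylsulfanyl or a dimethylamino group on the same aryl ring would separate these.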